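Amine substituent variation across three inactive analogues

A few compounds are considered here, and "the series" means these few. Any claim that something is new, unique, unknown or untested is made for them only; others in the source may bear on it.

Compound 1 `O=C1C=C(NCc2ccccc2)C(=O)c2c1nc1n2[C@H]2OC[C@@H](O)[C@H]2OC1` carries a benzylamino group on the shared core. In a functional assay on HeLa cells (Homo sapiens) for inhibition, read by sulforhodamine B assay (on this read-out lower numbers stand for stronger inhibition and higher numbers for weaker inhibition), compound 1 gives > 8000 nM, which is a limit of the assay and not a number. Compound 2 `O=C1C(NC2CCCC2)=CC(=O)c2c1nc1n2[C@H]2OC[C@@H](O)[C@H]2OC1` bears a cyclopentyl group on the amine nitrogen. In this assay compound 2 gives > 16000 nM, again a limit. Compound 3 `COc1ccc(NC2=CC(=O)c3c(nc4n3[C@H]3OC[C@@H](O)[C@H]3OC4)C2=O)cc1` carries 4-methoxyphenyl on the same nitrogen. In this assay compound 3 gives > 8000 nM, also a limit. The step that the two limits leave unreadable from compound 2 to compound 3 therefore cannot be sized: two of the values sit at the limit of > 8000 nM in this assay, at which 2 of the 3 values shown sit, and one at the limit of > 16000 nM in this assay, at which 1 of the 3 values shown sits, so compound 1 stands at a limit alongside the others, and no ordering among the three can be read.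

Compound 4 `O=C1C=C(Nc2cccc(Cl)c2)C(=O)c2c1nc1n2[C@H]2OC[C@@H](O)[C@H]2OC1` differs from compound 1 by 3-chlorophenyl in place of benzyl on an amine nitrogen. Going by the values given here, no measured step in this assay compares a benzyl with an aryl group on that nitrogen; the only step that changes the amine substituent, a step that the two limits leave unreadable from compound 2 to compound 3, is unreadable. Every measured analogue stays at a limit, the aryl-substituted compound 3 included. The step that the limit leaves unreadable from compound 1 to compound 4 is accordingly expected to be small and unreadable in this assay. Compound 4 is expected to give 12000 nM in this assay, within 4000 nM to 40000 nM, most likely reported as a limit again.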

Compound 4, half-maximal inhibitory concentration: 6040 nM
Compound 4: the middle estimate sits 2.0-fold (0.30 log units) above what was measured, within the range that was stated.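

In this assay compound 4 gives 6040 nM, the only actual number among the four compounds shown, so a substituent on this amine nitrogen can give a read-out that is not a limit. The change from benzyl to 3-chlorophenyl reads as an at least 1.3-fold lower number from compound 1 to compound 4 (0.12 log units; that floor lies within the scatter), so the size of the change is bounded on one side only and the printed floor does not by itself establish a real difference. Compound 1 and compound 3, the latter carrying 4-methoxyphenyl on the same nitrogen, both remain at a limit and not at a number, so an aryl group here does not by itself give a measurable value: the limit of > 8000 nM in this assay, at which 2 of the 4 values shown sit.

Going by these compounds, what remains open is whether the chlorine or the direct attachment of the aryl ring to the nitrogen accounts for the value of compound 4, and a plain phenyl or a 3-chlorobenzyl group on this nitrogen would separate the two. Also open, on these data alone, is how the read-out responds to other groups at this place, such as 3-bromophenyl, 3-methoxyphenyl or a longer chain ending in an amine.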